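The source may hold more compounds than are shown below. What is called first, only, known or untested is meant among the compounds shown, and "the series" means these compounds.

Measured so far in an ADME assay on L02 cells (Homo sapiens) for cytotoxicity, read by MTT assay, with a stated time of 48 h; a higher number here means a weaker inhibitor, a lower number a stronger inhibitor:
- compound 1 `O=C1O[C@@H](CN2CCCCC2)CN1c1ccc(-n2cc(-c3ccccn3)cn2)c(F)c1`, with a limit of the assay rather than a number: > 400 ug/mL
- compound 2 `O=C1CCC(=O)N1C[C@H]1CN(c2ccc(-n3cc(-c4ccccn4)cn3)c(F)c2)C(=O)O1`, likewise only a limit: > 400 ug/mL
- compound 3 `O=C1O[C@@H](CSc2cccs2)CN1c1ccc(-n2cc(-c3ccccn3)cn2)c(F)c1`, again only a limit: > 400 ug/mL

Compound 3 therefore stands at the limit and not at a number in this assay. Its shared core carries, on a saturated chain carbon bound to a saturated ring carbon, a (thiophen-2-yl)sulfanyl group where compound 1 has piperidin-1-yl and compound 2 has 2,5-dioxopyrrolidin-1-yl. The measured steps a step that the two limits leave unreadable from compound 1 to compound 2, a step that the two limits leave unreadable from compound 1 to compound 3 and a step that the two limits leave unreadable from compound 2 to compound 3 are all unreadable in size, because of the limit of > 400 ug/mL in this assay, at which 3 of the 3 values shown sit.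

Compound 4 `NC(=O)[C@H]1CN(c2ccc(-n3cc(-c4ccccn4)cn3)c(F)c2)C(=O)O1` differs from compound 3 as follows: carbamoyl in place of ((thiophen-2-yl)sulfanyl)methyl on a saturated ring carbon. For the measured compounds named here, none of the measured steps reads as a number, so none sets a size for this change; they only show that three variations at this position stayed at the limit. For compound 4 the expected step is a step that the limit leaves unreadable from compound 3 to compound 4, none beyond the scatter. Compound 4 is expected to sit at 500 ug/mL, within 200 ug/mL to 1500 ug/mL, most likely again reported only as a limit.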

Compound 4, half-maximal inhibitory concentration: 119 ug/mL
Estimate against measurement, compound 4: 4.2-fold (0.62 log units) above; measured number outside the range, below it.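

In this assay, the saturated ring carbon next to the ring oxygen now gives a readable change, with carbamoyl there producing an at least 3.3-fold lower number from compound 3 to compound 4 (0.52 log units; beyond the scatter), an at least 3.3-fold lower number from compound 2 to compound 4 (0.52 log units; beyond the scatter) and an at least 3.3-fold lower number from compound 1 to compound 4 (0.52 log units; beyond the scatter). So this position is not indifferent to its substituent, although the three side chains of compound 1, compound 2 and compound 3 could not be told apart. Those three remain unranked, and the steps among them still cannot be read, because their values are limits: the limit of > 400 ug/mL in this assay, at which 3 of the 4 values shown sit.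

The compounds shown leave open whether the lower number goes with the carbamoyl group itself or with the loss of the chain carbon that compound 1, compound 2 and compound 3 carry at this position. A carbamoylmethyl group or a carboxylic acid on that ring carbon would help separate these two readings.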